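Phenyl in Place of Hydroxy on a Seven-Membered Ring

The source may hold more compounds than are shown below. What is called first, only, known or untested is meant among the compounds shown, and "the series" means these compounds.

Measured so far:
Compound 1, `CCOC(=O)C(=O)Nc1ccccc(O)c1=O`: 5%
Compound 2, `CCOC(=O)C(=O)Nc1ccccc(OC)c1=O`: 24%

Both compounds were tested in a functional assay on the whole organism (strain Sprague-Dawley CD) for inhibition, with Rattus norvegicus as the target, read by paw edema, at a dose of 10 mg/kg by the intraperitoneal route; on this read-out lower numbers stand for a weaker effect and higher numbers for a stronger effect at the one dose given. In this assay compound 1 gives 5%, the lowest of the two numbers, and compound 2 gives 24%. Among the measured compounds shown here, the only change between them is methyl in place of hydrogen on an oxygen on an aromatic ring, and that change produced a number 19 percentage points higher from compound 1 to compound 2 (beyond the scatter).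

Compound 3, `CCOC(=O)C(=O)Nc1ccccc(-c2ccccc2)c1=O`, is not yet measured. It differs from compound 1 in one place: phenyl in place of hydroxy on an aromatic carbon. For the measured compounds named here, the one measured step that bears on this change is the one in which the hydroxy of compound 1 was capped; that step was modest and went upward. Going by the values given here, replacing the hydroxy altogether is a larger alteration of the same spot, so a step of similar size, upward, is expected, though the single precedent leaves the range wide.

Compound 3 is therefore estimated to give 22% in this assay, within 0% to 45%. This estimate means an expected a number 17 percentage points higher from compound 1 to compound 3 (beyond the scatter).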

Compound 3, a percentage reported as inhibition, in the whole organism at one dose (the size of the read-out at that dose, not a potency): 57%
The estimate for compound 3 lay 35 percentage points below the measured number, and the stated range ends below it.
By their numbers in this assay, from the lowest: compound 1; then compound 2; then compound 3.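

In this assay, this position proves far more responsive than the methyl cap on the oxygen alone could show: phenyl in place of hydroxy gives a number 52 percentage points higher from compound 1 to compound 3 (beyond the scatter), and phenyl in place of methoxy gives a number 33 percentage points higher from compound 2 to compound 3 (beyond the scatter). Both steps are large, so an oxygen attached at this aromatic carbon is not needed for the effect at this dose, and compound 3, with its six-membered aromatic ring of carbon only and no counted hydrogen-bond donors or acceptors at this spot, stands highest of the three. Nothing available explains why the phenyl group has this effect on paw edema.

With only hydroxy, methoxy and phenyl at this carbon, the compounds shown cannot separate the contribution of the larger number of heavy atoms from that of the aromatic ring or the loss of the oxygen. A cyclohexyl ring, a longer chain such as butyl, or an amine at the same place would test those possibilities, while a single dose leaves the potency of compound 3 open.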